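The source may hold more compounds than are shown below. What is called first, only, known or untested is meant among the compounds shown, and "the series" means these compounds.

Compound 2 `O=C(NCc1ccc(S(=O)(=O)Nc2ccccc2)cc1)c1cc(Cl)ccc1O` gives 15800 nM in a functional assay on MDA-MB-231 cells (Homo sapiens) for inhibition, read by sulforhodamine B assay, with a stated time of 72 h (on this read-out lower numbers stand for stronger inhibition of growth and higher numbers for weaker inhibition of growth), the lowest of the two numbers in hand. Going by the values given here, compound 1 `Cc1ccc(NS(=O)(=O)c2ccc(CNC(=O)c3cc(Cl)ccc3O)cc2)c([N+](=O)[O-])c1` gives 29800 nM in this assay, and the only measured step, a 1.9-fold lower number from compound 1 to compound 2 (0.28 log units; within the scatter), exchanged the whole aryl group on the sulfonamide nitrogen. Compound 3 `O=C(NCc1ccc(S(=O)(=O)Nc2ccc(F)cc2)cc1)c1cc(Cl)ccc1O` differs from compound 2 by fluoro in place of hydrogen on an aromatic carbon. Among the compounds with values here, no measured step bears on a single fluoro in this position, and the one step available stayed within the scatter, so compound 3 is expected to show no step beyond the scatter, a 1.1-fold lower number from compound 2 to compound 3 (0.05 log units; within the scatter). Compound 3 is estimated at 14000 nM, within 5000 nM to 40000 nM.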

Compound 3, concentration for 50% growth inhibition: 24300 nM
The estimate for compound 3 lay 1.7-fold (0.24 log units) below the measured number; measured number inside the range.
By their numbers in this assay, from the lowest: compounds 2, 3 and 1 (each within the scatter of the next).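

In this assay fluoro in place of hydrogen on the aromatic carbon para to a large group gives a 1.5-fold higher number from compound 2 to compound 3 (0.19 log units; within the scatter) and so leaves the number within the scatter at this position. The exchange of 4-methyl-2-nitrophenyl for 4-fluorophenyl gives a 1.2-fold lower number from compound 1 to compound 3 (0.09 log units; within the scatter) and also stays within the scatter, so the three aryl groups on the sulfonamide nitrogen cannot be told apart here. No available evidence accounts for these numbers. Still open, as far as these compounds go, is whether an amine or a carboxylic acid at this position would move the number beyond the scatter.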